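Adding a second fluoro to the aryl urea of compound 2

The source may report more compounds than this note shows. Statements on the series, on what has been measured and on what is new or still open speak of the compounds shown alone.

Compound 2 `Cc1cc(NC(=O)Nc2ccc(F)cc2)c2ccccc2n1` is a quinoline urea carrying a 4-fluorophenyl group. In an ADME assay on BJ cells (Homo sapiens) for cytotoxicity, with a stated time of 72 h (a lower number here means that less compound is needed, a higher number that more compound is needed for the effect), compound 2 gives only a limit, > 25000 nM. Compound 1 `Cc1cc(NC(=O)Nc2ccccc2F)c2ccccc2n1` likewise gives only a limit in this assay, > 25000 nM. Compound 3 `Cc1cc(NC(=O)Nc2ccc(N(C)C)cc2)c2ccccc2n1` also returns only a limit, > 25000 nM. The change from compound 1 to compound 2 (a step that the two limits leave unreadable from compound 1 to compound 2) and from compound 2 to compound 3 (a step that the two limits leave unreadable from compound 2 to compound 3) therefore cannot be sized, because of the limit of > 25000 nM in this assay, at which 3 of the 3 values shown sit. Compound 4 `Cc1cc(NC(=O)Nc2ccc(F)cc2F)c2ccccc2n1` differs from compound 2 by fluoro in place of hydrogen on an aromatic carbon. For the measured compounds named here, no measured step bears on this change. With three limits in hand, compound 4 is expected to remain at the limit, so the step that the limit leaves unreadable from compound 2 to compound 4 is estimated as none beyond the scatter. Compound 4 is estimated at 30000 nM, between 10000 nM and 100000 nM.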

Compound 4, half-maximal effective concentration: 20000 nM
Estimate against measurement, compound 4: 1.5-fold (0.18 log units) above; the measured number falls inside the stated range.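

With fluoro on the aromatic carbon ortho to a large group and meta to a fluoro group, compound 4 is the only compound shown in this assay that gives a number and not a limit, 20000 nM. This allows a floor to be put on two steps, an at least 1.2-fold lower number from compound 2 to compound 4 (0.09 log units; that floor lies within the scatter) and an at least 1.2-fold lower number from compound 1 to compound 4 (0.09 log units; that floor lies within the scatter), though neither floor goes beyond the scatter. The steps among compound 1, compound 2 and compound 3 still cannot be read: the limit of > 25000 nM in this assay, at which 3 of the 4 values shown sit.

On these data alone, the true size of both floored steps remains open. So does what a chloro group, a methoxy group or an amine would do at this position.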